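The source may report more compounds than this note shows. Statements on the series, on what has been measured and on what is new or still open speak of the compounds shown alone.

Compound 2 `CNC(=O)NC[C@H]1O[C@@H](n2cnc3c(NC(=O)Nc4ccccc4)ncnc32)[C@H](O[Si](C)(C)C(C)(C)C)[C@@H]1CC(=O)N(C)OC` and compound 1 `CCOC(=O)C[C@H]1[C@@H](O[Si](C)(C)C(C)(C)C)[C@H](n2cnc3c(NC(=O)Nc4ccccc4)ncnc32)O[C@@H]1COC(=O)NC` share a core and differ at two places. Going by the values given here, in a functional assay on IGROV-1 cells (Homo sapiens) for antiproliferative activity (on this read-out lower numbers stand for stronger inhibition of growth and higher numbers for weaker inhibition of growth), compound 2 gives 3.72 nM, the lowest of the two numbers so far; compound 1 gives 13.7 nM in this assay, a gap that lies beyond the scatter of repeated measurements. Among the compounds with values here, no single-change step between measured compounds is available, so each of the two differences cannot be weighed on its own.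

Compound 3 `CCOC(=O)C[C@H]1[C@@H](O[Si](C)(C)C(C)(C)C)[C@H](n2cnc3c(NC(=O)Nc4ccccc4)ncnc32)O[C@@H]1CNC(=O)NC` has not yet been measured. It is reached from compound 2 by one change: ethoxy in place of methoxy(methyl)amino on a carbonyl carbon. Compound 1 also carries an ethoxycarbonyl group, and its weaker number is the only hint of what this exchange might do, though it differs from compound 2 elsewhere too. The step from compound 2 to compound 3 is therefore expected to be a 2.2-fold higher number from compound 2 to compound 3 (0.33 log units; beyond the scatter), a modest rise in the number that may or may not exceed the scatter. Compound 3 is expected to give 8 nM in this assay, within a range from 3 nM to 25 nM.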

Compound 3, concentration for 50% growth inhibition: 3.85 nM
Compound 3: middle estimate off by 2.1-fold (0.32 log units), on the high side; the measured number falls inside the stated range.
By their numbers in this assay, from the lowest: compounds 2 and 3 (each within the scatter of the next); then compound 1.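

In this assay, placing ethoxy in position of methoxy(methyl)amino on the carbonyl carbon gives a 1.0-fold higher number from compound 2 to compound 3 (0.01 log units; within the scatter), so this exchange leaves the number within the scatter and the ethoxycarbonyl group does not by itself go with a weaker number. Going by these compounds alone, the second step, a 3.6-fold lower number from compound 1 to compound 3 (0.55 log units; beyond the scatter), puts (methylcarbamoyl)amino in place of (methylcarbamoyl)oxy on a saturated chain carbon bound to a saturated ring carbon, and it is the first single change here to go beyond the scatter, which ties the weaker number of compound 1 to this place and not to the ethoxycarbonyl group. Nothing on hand explains either step.

From the compounds shown here alone, both groups compared on the carbonyl carbon have no ring and no hydrogen-bond donors, so it remains open whether a carboxylic acid, a primary amide or a longer chain such as butoxy would also leave the number within the scatter. Going by these compounds, whether the second step would hold with methoxy(methyl)amino on the carbonyl carbon also remains open, as does what a plain amine on that chain carbon would give.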